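The compounds below may be only part of what the source reports. "The series", "measured", "known", "first", "only" and "open" are said of these compounds alone.

Measured compounds:
- compound 1 `Cc1cc(C(=O)Nc2c(F)cccc2F)nn1Cc1cc(Cl)ccc1OCc1ccccc1`
- compound 2 `Cc1cc(C(=O)NCc2ccncc2)nn1Cc1cc(Cl)ccc1OCc1ccccc1`
- compound 3 `CC(=O)Nc1cc(C)n(Cc2cc(Cl)ccc2OCc2ccccc2)n1`

In a physicochemical assay for lipophilicity, at pH 7.4 (a lower number here means a more polar compound, a higher number a more lipophilic compound), compound 1 gives 3.7. Compound 2 gives only a limit of the assay in this assay, namely > 3.7. Compound 3 likewise gives only a limit of the assay in this assay, namely > 3.7. Compound 3 thus stands at the limit of > 3.7 in this assay, at which 2 of the 3 values shown sit, and nothing in the numbers sets it apart from compound 2. Of the measured steps, a number no lower from compound 1 to compound 3 (the limit leaves the size open) exchanges the same two groups as the step now followed, only in the other direction, while a number no lower from compound 1 to compound 2 (the limit leaves the size open) and a step that the two limits leave unreadable from compound 2 to compound 3 also run into the limit; none of the three has a readable size.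

Compound 4 `Cc1cc(NC(=O)c2c(F)cccc2F)nn1Cc1cc(Cl)ccc1OCc1ccccc1` differs from compound 3 by 2,6-difluorophenyl in place of methyl on a carbonyl carbon, so that the acetamido becomes ((2,6-difluorophenyl)carbonyl)amino. Within the data shown here, because compound 3 already sits at the limit > 3.7, compound 4 is expected to end at or beyond that limit as well, with an estimated upward step that the limit leaves unreadable from compound 3 to compound 4 that no measured step can anchor. Compound 4 is therefore estimated at 4.5, between 3.8 and 5.3.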

Compound 4, distribution coefficient: > 3.7
Compound 4: a limit, no number; the forecaster's own chance of this, stated with the estimate: 90%; the middle value is on the limit's open side.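

In this assay compound 4 gives > 3.7 as a limit of the assay and not as a number. As far as these compounds go, none of the new steps to compound 4 can be read, so the size of the exchange of methyl for 2,6-difluorophenyl on a carbonyl carbon remains unknown. This position now shows only that ((2,6-difluorophenyl)carbonyl)amino, like the acetamido of compound 3, gives a limit rather than a number, and such results now make up most of the set: the limit of > 3.7 in this assay, at which 3 of the 4 values shown sit.

From the compounds shown here alone, how far compounds 2, 3 and 4 lie from one another remains open. Among these compounds, also open in this assay is the size of the one new step that has a direction, a number no lower from compound 1 to compound 4 (the limit leaves the size open).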